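Dropping a Methyl from the Least Active Compound

The source may report more compounds than this note shows. Statements on the series, on what has been measured and on what is new or still open speak of the compounds shown alone.

So far three related compounds have been tested in a functional assay on NSCLC cells (Homo sapiens) for cytotoxicity, with a stated time of 48 h; a lower number here means a stronger inhibitor of growth, a higher number a weaker inhibitor of growth. Compound 1 `COc1cc2c(/C=C3/C(=O)Nc4ccc(O)cc43)c(Cl)n(Cc3cc(OC)c(OC)c(OC)c3)c2cc1C` gives 32400 nM. Going by the values given here, compound 2 `COc1cc2c(/C=C3/C(=O)Nc4ccc(Cl)cc43)c(Cl)n(Cc3cc(OC)c(OC)c(OC)c3)c2cc1C` carries a chloro where compound 1 carries a hydroxy, and in this assay compound 2 gives 5890 nM; this is the only single-point change among the measured compounds, and it amounts to a 5.5-fold lower number from compound 1 to compound 2 (0.74 log units; beyond the scatter). Compound 3 `COc1cc2c(cc1C)NC(=O)/C2=C/c1c(Cl)n(Cc2cc(OC)c(OC)c(OC)c2)c2cc(C)c(OC)cc12` gives 66100 nM, the highest number of the three and so the weakest growth inhibitor here; compound 1 stands nearest to it and compound 2 furthest, both differences lying beyond the scatter.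

Compound 4 `COc1ccc2c(c1)/C(=C\c1c(Cl)n(Cc3cc(OC)c(OC)c(OC)c3)c3cc(C)c(OC)cc13)C(=O)N2` differs from compound 3 in one place: hydrogen in place of methyl on an aromatic carbon. The methyl that leaves sits on a six-membered aromatic ring of carbon only, part of a fused system of two rings, ortho to a methoxy group.

Among the compounds with values here, the one measured step, chloro for hydroxy, touches a different group at a different place, so it does not bear on this change. Within the data shown here, no measured pair speaks to removing a methyl, and the expectation therefore rests on the size of the group alone: a single carbon lost, no ring, no donor or acceptor. Compound 4 is expected to give about 55000 nM, within a range from 20000 nM to 150000 nM. This estimate amounts to an expected step of a 1.2-fold lower number from compound 3 to compound 4 (0.08 log units; within the scatter), not beyond the scatter.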

Compound 4, concentration for total growth inhibition: 97700 nM
The estimate for compound 4 lay 1.8-fold (0.25 log units) below the measured number; measured number inside the range.
By their numbers in this assay, from the lowest: compound 2; then compound 1; then compounds 3 and 4 (each within the scatter of the next).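

In this assay, taking the methyl off this aromatic carbon, ortho to a methoxy group, leaves a difference that lies within the scatter (a 1.5-fold higher number from compound 3 to compound 4 (0.17 log units; within the scatter)), so at this place the data do not separate methyl from hydrogen. Compound 4 also adds a third group at the place where compound 1 and compound 2 differ: methoxy in place of chloro gives a large step (a 17-fold higher number from compound 2 to compound 4 (1.22 log units; beyond the scatter)), and a methyl added to the oxygen of the hydroxy gives a modest one (a 3.0-fold higher number from compound 1 to compound 4 (0.48 log units; beyond the scatter)), so across these three compounds the number rises from chloro to hydroxy to methoxy, with each gap beyond the scatter. No measurement shown here gives a reason for either result.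

The compounds shown leave open what a group other than methyl or hydrogen would do on this aromatic carbon, such as an ethyl chain, an amine or a carboxylic acid. Also open, going by these compounds, is whether losing the methyl would still make so little difference with the chloro of compound 2 in place of the methoxy of compound 3.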